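Cyano to isopropyl on the terminal phenyl ring

A few compounds are considered here, and "the series" means these few. Any claim that something is new, unique, unknown or untested is made for them only; others in the source may bear on it.

Measured compounds:
Compound 1, `Cc1cccc(-n2cc(COc3cccc(NC(=O)Nc4ccc(Cl)c(C(F)(F)F)c4)c3)nn2)c1`, gives 7270 nM in a functional assay on HepG2 cells (Homo sapiens) for inhibition, read by MTT assay, with a stated time of 72 h; on this read-out lower numbers stand for stronger inhibition and higher numbers for weaker inhibition.
Compound 2, `N#Cc1cccc(-n2cc(COc3cccc(NC(=O)Nc4ccc(Cl)c(C(F)(F)F)c4)c3)nn2)c1`, gives 2760 nM in this assay.
Compound 3, `CCc1cccc(-n2cc(COc3cccc(NC(=O)Nc4ccc(Cl)c(C(F)(F)F)c4)c3)nn2)c1`, gives 37900 nM in this assay.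

Compound 2 has the lowest number of the three in this assay. Its nearest neighbour is compound 1, with a 2.6-fold lower number from compound 1 to compound 2 (0.42 log units; beyond the scatter); its furthest is compound 3, with a 14-fold higher number from compound 2 to compound 3 (1.14 log units; beyond the scatter). Both steps lie beyond the scatter, so compound 2 stands apart from the other two.

Compound 4 is `CC(C)c1cccc(-n2cc(COc3cccc(NC(=O)Nc4ccc(Cl)c(C(F)(F)F)c4)c3)nn2)c1`. It differs from compound 2 by isopropyl in place of cyano on an aromatic carbon. Within the data shown here, two measured steps bear on this. Within the alkyl series, a 5.2-fold higher number from compound 1 to compound 3 (0.72 log units; beyond the scatter) shows that lengthening the chain raises the number. The direct swap of cyano for an alkyl group is seen in a 14-fold higher number from compound 2 to compound 3 (1.14 log units; beyond the scatter), a large rise. Isopropyl goes one carbon beyond ethyl, and no measured compound carries it, so the size is extrapolated. The expectation in this assay is a large rise from compound 2, at least as large as the step to compound 3, and it is worded as an expected step of a 20-fold higher number from compound 2 to compound 4 (1.30 log units; beyond the scatter). Compound 4 is therefore estimated at 55000 nM. The expected range for compound 4 runs from 15000 nM to 180000 nM.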

Compound 4, half-maximal inhibitory concentration: 3250 nM
Compound 4: the middle estimate sits 17-fold (1.23 log units) above what was measured; the measured number lies below the stated range.
By their numbers in this assay, from the lowest: compounds 2 and 4 (each within the scatter of the next); then compound 1; then compound 3.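

In this assay, the change from 3-cyanophenyl to 3-isopropylphenyl leaves the number within the scatter, a 1.2-fold higher number from compound 2 to compound 4 (0.07 log units; within the scatter), so a nitrile is not required at this position for a number at this level, and an alkyl group can match it. The alkyl groups follow no simple order of size: the branched isopropyl group brings the number far down from that of the ethyl analogue, a 12-fold lower number from compound 3 to compound 4 (1.07 log units; beyond the scatter), and also takes it modestly under that of the methyl analogue, a 2.2-fold lower number from compound 1 to compound 4 (0.35 log units; beyond the scatter), so that the ethyl compound, not the largest group, gives the highest number of the series. The data shown offer no measurement that accounts for the ethyl compound standing apart from the other three.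

Open, from the compounds shown here alone, is whether that high number belongs to ethyl alone or recurs with an unbranched propyl or a longer chain, and whether a tert-butyl group continues the level seen with isopropyl. Also open, going by these compounds, is how an amine or a carboxylic acid at this position would read in this assay.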